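The source may hold more compounds than are shown below. What is called first, only, known or untested is meant among the compounds shown, and "the series" means these compounds.

Going by the values given here, in an assay on isolated protein for inhibition of Rho-associated protein kinase 2 (Homo sapiens), read by scintillation counting, radiometric assay and 33P incorporation, with a stated time of 40 min, in the presence of a further agent that is not named here (a higher number here means a weaker inhibitor, a lower number a stronger inhibitor), compound 2 `O=C(COc1ccc2c(=O)ccoc2c1)Nc1cccc(NC(=O)c2ccc(F)cc2)c1` gives 54 nM, the lowest of the three numbers measured so far. Compound 3 `CN(C)c1ccc(S(=O)(=O)Nc2cccc(NC(=O)COc3ccc4c(=O)ccoc4c3)c2)cc1` gives 263 nM in this assay, and compound 1 `CN(C)c1ccc(C(=O)Nc2cccc(NC(=O)COc3ccc4c(c3)CCC(=O)N4)c2)cc1` gives 9970 nM; both gaps to compound 2 lie beyond the scatter. Compound 3 and compound 1 each differ from compound 2 in more than one place, so neither of them supplies a single-change step in this assay.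

Compound 4 `Nc1cccc(C(=O)Nc2cccc(NC(=O)COc3ccc4c(=O)ccoc4c3)c2)c1` has not been measured. It differs from compound 2 in one place: 3-aminophenyl in place of 4-fluorophenyl on a carbonyl carbon. Among the compounds with values here, no measured pair isolates this exchange. The only hint on the shared core of compound 2 comes from compound 3, which carries a nitrogen-bearing ring attached through a sulfonyl group rather than a carbonyl and gives 263 nM, while compound 2 gives 54 nM; that comparison is not clean.

Because compound 2 gives 54 nM and the change keeps the ring size and the carbonyl linkage, the expected step from compound 2 to compound 4 in this assay is small, toward a somewhat weaker number, possibly within the scatter. Compound 4 is estimated at 110 nM, with a range from 30 nM to 400 nM. The expected step is a 2.0-fold higher number from compound 2 to compound 4 (0.31 log units; beyond the scatter).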

Compound 4, half-maximal inhibitory concentration: 58 nM
Compound 4: the middle estimate sits 1.9-fold (0.28 log units) above what was measured, and the stated range covers the measured number.
By their numbers in this assay, from the lowest: compounds 2 and 4 (each within the scatter of the next); then compound 3; then compound 1.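

In this assay the first single-change step among the compounds shown is a 1.1-fold higher number from compound 2 to compound 4 (0.03 log units; within the scatter) with 3-aminophenyl in place of 4-fluorophenyl on a carbonyl carbon. The position therefore accepts this exchange with no difference that can be told from the scatter, even though the entering group brings a hydrogen-bond donor and a hydrogen-bond acceptor that the leaving group does not have, at the same count of heavy atoms, so compound 2 and compound 4 cannot be placed in any order. Nothing available bears on why the two groups read alike here.

Going by these compounds alone, only this one exchange has been read at this position, so it remains open whether the result extends to other groups on the carbonyl carbon, such as a carboxylic acid, a methoxy-substituted phenyl ring or a longer chain in place of the ring. Compound 1 and compound 3 differ from compound 2 in more than one place, so any effect of the sulfonyl link or of the changed core cannot be read from them.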